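Swapping piperazine for a fused bicyclic amine on the benzoxazole core

The source may hold more compounds than are shown below. What is called first, only, known or untested is meant among the compounds shown, and "the series" means these compounds.

Measured compounds:
- compound 1, `CN(c1ccccc1)c1nc2cc(-c3ccc4c(ccn4C)c3)ccc2o1`: 68 nM
- compound 2, `COc1ccc(Nc2nc3cc(-c4ccc5c(ccn5C)c4)ccc3o2)cc1`: 280 nM
- compound 3, `Cn1ccc2cc(-c3ccc4oc(N5CCNCC5)nc4c3)ccc21`: > 1000 nM

All three share one core and differ only in the amine attached to it. In an assay on HEK293 cells for inhibition of Fatty-acid amide hydrolase 1 (Homo sapiens), read by fluorescence (on this read-out higher numbers stand for weaker inhibition and lower numbers for stronger inhibition), compound 1 gives 68 nM. In this assay compound 2 gives 280 nM, and the change is a 4.1-fold higher number from compound 1 to compound 2 (0.61 log units; beyond the scatter). For compound 3 the assay gives only a limit, > 1000 nM, as noted in the limit of > 1000 nM in this assay, at which 1 of the 3 values shown sits; compound 3 therefore stands weakest of the three, with steps of an at least 14-fold higher number from compound 1 to compound 3 (1.16 log units; beyond the scatter) and an at least 3.5-fold higher number from compound 2 to compound 3 (0.55 log units; beyond the scatter).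

The new compound 4, `Cn1ccc2cc(-c3ccc4oc(N5CCn6cccc6C5)nc4c3)ccc21`, differs from compound 3 by a group of 9 heavy atoms (7 carbon, 2 nitrogen; one five-membered aromatic ring with 1 hetero atom, one six-membered non-aromatic ring with 2 hetero atoms) in place of a group of 6 heavy atoms (4 carbon, 2 nitrogen; one six-membered non-aromatic ring with 2 hetero atoms), on an aromatic carbon. Among the measured compounds shown here, no measured step copies this exact swap. What the measured steps show is that the two compounds carrying an aromatic ring in the amine, compound 1 and compound 2, sit well below the limit, while the plain piperazine of compound 3 does not. The entering group of compound 4 brings a five-membered aromatic ring back into the amine, so some recovery toward the numbers of compound 1 and compound 2 is expected, though compound 3 gives only a limit and the true size of the step cannot be fixed.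

Compound 4 is therefore estimated at 600 nM, with a range from 150 nM to 3000 nM. That estimate corresponds to an expected step of an at least 1.6-fold lower number from compound 3 to compound 4 (0.22 log units; that floor lies within the scatter).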

Compound 4, half-maximal inhibitory concentration: 42 nM
Estimate against measurement, compound 4: 14-fold (1.15 log units) above; the whole stated range lies above it.
By their numbers in this assay, from the lowest: compounds 4 and 1 (each within the scatter of the next); then compound 2. At a limit, above all of these: compound 3.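

In this assay, keeping the six-membered non-aromatic ring of the piperazin-1-yl group and adding a five-membered aromatic ring to it gives an at least 23-fold lower number from compound 3 to compound 4 (1.37 log units; beyond the scatter). Among the compounds shown here, that step is only a floor, as compound 3 has a limit and not a number: the limit of > 1000 nM in this assay, at which 1 of the 4 values shown sits. The earlier compounds both carried a six-membered aromatic ring of carbon only in the amine, and compound 4 shows that this ring is not needed at this aromatic carbon of the core, with a 6.7-fold lower number from compound 2 to compound 4 (0.82 log units; beyond the scatter) and a 1.6-fold lower number from compound 1 to compound 4 (0.21 log units; within the scatter), so compound 1 and compound 4 cannot be told apart here.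

The compounds shown do not separate the effect of the five-membered aromatic ring itself from that of fusing it to the six-membered ring, and a piperazine carrying a plain phenyl or benzyl group would help to pull these two apart. On these data alone, it also stays open whether the ring nitrogen of the five-membered aromatic ring matters, which an imidazole or a thiophene fused in the same way could test.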